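The source may hold more compounds than are shown below. What is called first, only, known or untested is meant among the compounds shown, and "the series" means these compounds.

Compound 1 `O=c1ccoc2cc(OCc3cn(Cc4ccccc4)nn3)ccc12` is the starting point of this small set. Among the compounds with values here, in a functional assay on SW480 cells (Homo sapiens) for cytotoxicity, read by MTT assay, with a stated time of 48 h (a lower number here means a stronger inhibitor, a higher number a weaker inhibitor), compound 1 gives 42900 nM, the highest of the three numbers measured so far. Its two measured companions each carry a chloro group. Compound 2 `O=c1ccoc2cc(OCc3cn(Cc4cccc(Cl)c4)nn3)ccc12` gives 12900 nM and compound 3 `O=c1ccoc2cc(OCc3cn(Cc4ccccc4Cl)nn3)ccc12` gives 23500 nM. The step of a 3.3-fold lower number from compound 1 to compound 2 (0.52 log units; beyond the scatter) is modest but real, while the step of a 1.8-fold lower number from compound 1 to compound 3 (0.26 log units; within the scatter) stays within the scatter, as does the step of a 1.8-fold higher number from compound 2 to compound 3 (0.26 log units; within the scatter) between the two chloro compounds.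

Compound 4 `O=c1ccoc2cc(OCc3cn(Cc4ccc([N+](=O)[O-])cc4)nn3)ccc12` has not yet been measured. It differs from compound 1 by nitro in place of hydrogen on an aromatic carbon. Within the data shown here, no measured pair shows a nitro group entering, so the two chloro steps are the only guide. Because the step of a 3.3-fold lower number from compound 1 to compound 2 (0.52 log units; beyond the scatter) and the step of a 1.8-fold lower number from compound 1 to compound 3 (0.26 log units; within the scatter) both lowered the number by a small or modest amount, a shift of similar size downward is expected for compound 4, though it could also stay within the scatter. For compound 4 the estimated result is 20000 nM, with a plausible range from 8000 nM to 50000 nM. This corresponds to an expected step of a 2.1-fold lower number from compound 1 to compound 4 (0.33 log units; beyond the scatter).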

Compound 4, half-maximal inhibitory concentration: 19300 nM
Compound 4: the middle estimate sits 1.0-fold (0.02 log units) above what was measured, within the range that was stated.
By their numbers in this assay, from the lowest: compounds 2, 4, 3 and 1 (each within the scatter of the next, the first and the last beyond it).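

In this assay, putting a group at a new place on the ring, para to a large group, and using a group other than chloro still gives a real change: the step of a 2.2-fold lower number from compound 1 to compound 4 (0.35 log units; beyond the scatter) is modest but clear. Compound 4 also falls in with the two chloro compounds, since neither the step of a 1.2-fold lower number from compound 3 to compound 4 (0.09 log units; within the scatter) nor the step of a 1.5-fold higher number from compound 2 to compound 4 (0.17 log units; within the scatter) can be told apart from repeat-measurement noise. Nothing measured here explains why these different groups at different places give such similar results.

Within the data shown here, with only one compound at this place, the role of the place cannot be separated from that of the nitro group. On these data alone, it also remains open whether an amine or a carboxylic acid at this same place would lower the number as well.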